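The compounds below may be only part of what the source reports. "The series", "measured", "known", "first", "only" and "open" are said of these compounds alone.

Measured compounds:

Compound 1, `CCOC(=O)c1c(-c2cc3ccccc3oc2=O)nn(-c2cccc(C)c2)c1C(=O)OCC`, gives 52000 nM in a functional assay on A549 cells (Homo sapiens) for cytotoxicity, read by MTT assay, with a stated time of 48 h; a higher number here means a weaker inhibitor, a lower number a stronger inhibitor.
Compound 2, `COC(=O)c1c(-c2cc3ccccc3oc2=O)nn(-c2cccc(C)c2)c1C(=O)OC`, gives 51000 nM in this assay.
Compound 3, `CCOC(=O)c1c(-c2cc3ccccc3oc2=O)nn(-c2cccc(Cl)c2)c1C(=O)OCC`, gives 28000 nM in this assay.

Compound 1 and compound 2 share most of their build but carry different cores; the difference between the two cores is not broken down here. Their values in this assay sit close together, and the two numbers read almost the same.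

Compound 3 is compound 1 with one small change, (chloro in place of methyl on an aromatic carbon). The step that this change made in this assay is a 1.9-fold lower number from compound 1 to compound 3 (0.27 log units; within the scatter), a movement that stays inside the usual scatter of repeated measurements, so it cannot be read as a real gain.

Compound 4, `COC(=O)c1c(-c2cc3ccccc3oc2=O)nn(-c2cccc(Cl)c2)c1C(=O)OC`, is not yet measured. It stands to compound 2 as compound 3 stands to compound 1: the change is chloro in place of methyl on an aromatic carbon. The place of the change is described in the same words for both pairs, so this is the same change, only made on the core of compound 2 instead of the core of compound 1.

For the measured compounds named here, the expected step from compound 2 to compound 4 in this assay is a 1.9-fold lower number from compound 2 to compound 4 (0.28 log units; within the scatter), and this expectation rests on the one earlier instance of the change, because a 1.9-fold lower number from compound 1 to compound 3 (0.27 log units; within the scatter). For compound 4 the expected value in this assay is 27000 nM. The expected range for compound 4 runs from 12000 nM to 60000 nM.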

Compound 4, half-maximal inhibitory concentration: 30000 nM
The estimate for compound 4 lay 1.1-fold (0.05 log units) below the measured number; the range from low to high includes it.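

The swap of 3-methylphenyl for 3-chlorophenyl reads in this assay as a 1.7-fold lower number from compound 2 to compound 4 (0.23 log units; within the scatter), so this step is small and cannot count as a real change in potency on its own. Set beside the earlier instance of the same swap, it shows that the change behaves alike on the two cores, with no sign that the choice of core alters its effect: the same change on two cores in this assay, a 1.9-fold lower number (0.27 log units; within the scatter) from compound 1 to compound 3 and a 1.7-fold lower number (0.23 log units; within the scatter) from compound 2 to compound 4, 1.1-fold (0.04 log units) apart, within the scatter of two such steps What this does not show is that chloro truly improves on methyl, since neither step rises above the scatter, and two pairs in a single cell assay cannot establish a rule for the wider series.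

The compounds shown carry only methyl or chloro in this place on the aromatic ring, so it remains open whether an amine, a carboxylic acid or a longer chain such as butyl there would move the number by more than the scatter. As far as these compounds go, it also remains open whether a change that does produce a clear step on one core would carry over to the other as closely as this small one does.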